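The source may report more compounds than this note shows. Statements on the series, on what has been measured and on what is new or still open speak of the compounds shown alone.

Two triphosphate nucleotides open the comparison. Compound 1 `O=c1ccn([C@@H]2O[C@H](COP(=O)(O)OP(=O)(O)OP(=O)(O)O)[C@@H](O)[C@H]2O)c(=S)[nH]1` gives 1500 nM in an in vitro functional assay on 1321-N1 cells for agonist activity at P2Y purinoceptor 6 (Homo sapiens) (on this read-out lower numbers stand for an effect already at smaller amounts and higher numbers for an effect only at larger amounts of compound), while compound 2 `Nc1cn([C@@H]2O[C@H](COP(=O)(O)OP(=O)(O)OP(=O)(O)O)[C@@H](O)[C@H]2O)c(=O)[nH]c1=O` gives 333 nM; the change of the whole base brought a 4.5-fold lower number from compound 1 to compound 2 (0.65 log units; beyond the scatter). Compound 2 therefore holds the lower of the two numbers. Compound 3 `[N-]=[N+]=Nc1cn([C@@H]2O[C@H](COP(=O)(O)OP(=O)(O)OP(=O)(O)O)[C@@H](O)[C@H]2O)c(=O)[nH]c1=O` keeps the core of compound 2 and carries azido in place of amino on an aromatic carbon. Within the data shown here, no measured step alters this ring position, so the base swap offers only loose guidance, and the expected step of a 1.2-fold higher number from compound 2 to compound 3 (0.08 log units; within the scatter) is small. Compound 3 is accordingly estimated at 400 nM, within 150 nM to 1100 nM.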

Compound 3, half-maximal effective concentration: 467 nM
Beside the measured number, compound 3's estimate is 1.2-fold (0.07 log units) below it; low and high end bracket the measured number.
By their numbers in this assay, from the lowest: compounds 2 and 3 (each within the scatter of the next); then compound 1.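

Placing azido in place of amino on this aromatic carbon gives a 1.4-fold higher number from compound 2 to compound 3 (0.15 log units; within the scatter) in this assay. This ring position therefore takes the larger azido group, with 0 hydrogen-bond donors, and the number stays within the scatter. The data offer no measured explanation for why these two groups read alike.

Still open, on these data alone, is how this position responds to groups of other kinds, such as a methyl, a bromine, a carboxylic acid or a longer chain. Two groups that read alike cannot show how far this tolerance extends.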